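Two Aryl Swaps on One Amide Core

The source may report more compounds than this note shows. Statements on the series, on what has been measured and on what is new or still open speak of the compounds shown alone.

The measured compounds and their values in a functional assay on HL-60 cells (Homo sapiens) for inhibition, read by MTT assay, with a stated time of 72 h (a higher number here means a weaker inhibitor, a lower number a stronger inhibitor), are:

Compound 1, `Cc1ccc(C)c(N2CCN(C(=O)c3oc(C)nc3-c3ccccc3)CC2)c1`: 31.3 nM
Compound 2, `COc1cccc(N2CCN(C(=O)c3oc(C)nc3-c3ccccc3)CC2)c1`: 34.8 nM
Compound 3, `COc1cccc(N2CCN(C(=O)c3oc(C)nc3-c3cccc(F)c3)CC2)c1`: "not active" (no number reported)

All three share the same core, and differ only in two places. From compound 2 to compound 1 the change is 2,5-dimethylphenyl in place of 3-methoxyphenyl on an amine nitrogen in a ring. The step of a 1.1-fold lower number from compound 2 to compound 1 (0.05 log units; within the scatter) shows that this change left the result essentially where it was. From compound 2 to compound 3 the change is fluoro in place of hydrogen on an aromatic carbon. Here compound 2 gives a number, while compound 3 was reported as not active, so no step can be counted between them.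

Compound 4, `Cc1ccc(C)c(N2CCN(C(=O)c3oc(C)nc3-c3cccc(F)c3)CC2)c1`, has not yet been measured in this assay. It differs from compound 3 by 2,5-dimethylphenyl in place of 3-methoxyphenyl on an amine nitrogen in a ring, and the place of this change is the same, word for word, as in the pair compound 2 to compound 1: it is the same change, made on the core that carries the fluoro group. Since that change produced a 1.1-fold lower number from compound 2 to compound 1 (0.05 log units; within the scatter), a step of similar small size is expected from compound 3 to compound 4. With compound 3 reported as not active, compound 4 is therefore expected to be weak as well, and quite possibly to be reported again without a number. The estimate for compound 4 in this assay is 30000 nM, with a range from 5000 nM to 100000 nM.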

Compound 4, half-maximal inhibitory concentration: 204 nM
Beside the measured number, compound 4's estimate is 150-fold (2.17 log units) above it; the measured number lies below the stated range.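

In this assay the swap of fluoro for hydrogen on an aromatic carbon gives a 6.5-fold higher number from compound 1 to compound 4 (0.81 log units; beyond the scatter) and so weakens the result on the core of compound 1, yet still leaves a measurable number. On the core of compound 2 the same swap leads to compound 3, reported as not active, so the fluoro group goes the same way on both cores, but the steps from compound 2 to compound 3 and from compound 3 to compound 4 cannot be read, and the size of the fluoro change on the two cores cannot be compared. The aryl change gives a 1.1-fold lower number from compound 2 to compound 1 (0.05 log units; within the scatter) and so makes no clear difference without the fluoro group, while with it compound 4 has a number and compound 3 has none, a contrast that no measurement shown here explains.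

These few compounds leave open whether chloro or a nitrile in place of the fluoro would give the same weakening on both cores. They also leave open whether a plain phenyl or a 3-methylphenyl on the amine nitrogen would behave like 2,5-dimethylphenyl or like 3-methoxyphenyl once the fluoro group is present.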